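The source may hold more compounds than are shown below. What is called first, only, known or untested is meant among the compounds shown, and "the series" means these compounds.

- Compound 1 `COCCc1nc2nc(C)cc(Nc3ccc(S(F)(F)(F)(F)F)cc3)n2n1`: 87.7%
- Compound 2 `Cc1cc(Nc2ccc(Cl)cc2)n2nc(C(C)C)nc2n1`: 84.9%

In an ADME assay on a cell-free system (plasma, Homo sapiens) for protein binding, compound 1 gives 87.7% and compound 2 gives 84.9%, so the two values lie within the scatter of each other. Compound 3 `CCOc1nc2nc(C)cc(Nc3ccc(S(F)(F)(F)(F)F)cc3)n2n1` has ethoxy in place of 2-methoxyethyl on an aromatic carbon of compound 1: ethoxy in place of 2-methoxyethyl on an aromatic carbon. Within the data shown here, no measured pair differs in only one place, so this change has no direct precedent here. The expectation is a step no larger than the scatter, with no clear direction: a 1.0-fold lower unbound fraction from compound 1 to compound 3 (0.01 log units; within the scatter). In this assay, compound 3 is estimated at 88%, with an expected range from 79% to 94%.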

Compound 3, plasma protein binding: 97.7%
For compound 3 the middle estimate is 5.2-fold (0.72 log units) (unbound fraction) above the measured one; measured number above the stated range.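

In this assay, putting ethoxy in place of 2-methoxyethyl gives a 5.3-fold lower unbound fraction from compound 1 to compound 3 (0.73 log units; beyond the scatter) even though both groups have the same counts of hydrogen-bond donors and acceptors and neither carries a net charge. This carbon between two ring nitrogen atoms is therefore sensitive to a small change in its group, at least on the core of compound 1. Nothing measured here explains the shift. On these data alone, whether an amine or a carboxylic acid at this position would also change binding remains open, and so does the effect of a longer alkoxy chain.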